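An Unreadable Step Repeated on a Second Core

The source may hold more compounds than are shown below. What is called first, only, known or untested is meant among the compounds shown, and "the series" means these compounds.

Three compounds have been measured in an ADME assay on THP-1 cells (Homo sapiens) for cytotoxicity, read by flow cytometry, with a stated time of 72 h; on this read-out lower numbers stand for stronger inhibition and higher numbers for weaker inhibition:
compound 1 `N/C(=N\O)c1ccc(C2=C(S(=O)(=O)c3ccc(Nc4cccc(/C(N)=N/O)c4)cc3)CC(c3ccccc3)(c3ccccc3)O2)cc1`, > 50000 nM;
compound 2 `CC1(Cc2ccccc2)CC(S(=O)(=O)c2ccc(Nc3cccc(/C(N)=N/O)c3)cc2)=C(c2ccc(/C(N)=N/O)cc2)O1`, 46600 nM;
compound 3 `N/C(=N\O)c1ccc(C2=C(S(=O)(=O)c3ccc(Nc4ccccc4/C(N)=N/O)cc3)CC(c3ccccc3)(c3ccccc3)O2)cc1`, > 50000 nM.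

In this assay compound 1 gives > 50000 nM, which is a limit of the assay and not a number. Compound 3 likewise gives > 50000 nM, again a limit. Compound 3 arises from compound 1 by one change, (a group of 10 heavy atoms (7 carbon, 2 nitrogen, 1 oxygen; one six-membered aromatic ring of carbon only) in place of a group of 10 heavy atoms (7 carbon, 2 nitrogen, 1 oxygen; one six-membered aromatic ring of carbon only), on a nitrogen on an aromatic ring). The measured step, a step that the two limits leave unreadable from compound 1 to compound 3, cannot be sized because of the limit of > 50000 nM in this assay, at which 2 of the 3 values shown sit.

Compound 2 stands on a different core; the difference between the two cores is not broken down here. In this assay, among the measured compounds shown here, compound 2 gives 46600 nM, the only number among the three.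

Compound 4 `CC1(Cc2ccccc2)CC(S(=O)(=O)c2ccc(Nc3ccccc3/C(N)=N/O)cc2)=C(c2ccc(/C(N)=N/O)cc2)O1` has not yet been measured. It relates to compound 2 by the same change, (a group of 10 heavy atoms (7 carbon, 2 nitrogen, 1 oxygen; one six-membered aromatic ring of carbon only) in place of a group of 10 heavy atoms (7 carbon, 2 nitrogen, 1 oxygen; one six-membered aromatic ring of carbon only), on a nitrogen on an aromatic ring), at the same place. The expected step is a 1.1-fold higher number from compound 2 to compound 4 (0.03 log units; within the scatter), which rests on compound 2 sitting at 46600 nM while the earlier step that the two limits leave unreadable from compound 1 to compound 3 gave no readable size. Compound 4 is expected at 50000 nM, between 25000 nM and 100000 nM, with a fair chance that only a limit is reported.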

Compound 4, half-maximal inhibitory concentration: 48400 nM
For compound 4 the middle estimate is 1.0-fold (0.01 log units) above the measured one; measured number inside the range.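

On the core of compound 2, the exchange of one group for the other on the nitrogen on an aromatic ring can be read, and in this assay it gives a 1.0-fold higher number from compound 2 to compound 4 (0.02 log units; within the scatter) and so does not separate the two compounds. This shows that on this core the change leaves the number where it was, within the usual scatter of the measurement. It does not show that the change carries from one core to the other, for no size can be set beside it, because the step on the core of compound 1 cannot be read: the limit of > 50000 nM in this assay, at which 2 of the 4 values shown sit.

From the compounds shown here alone, it remains open whether a different group on that nitrogen, such as one bearing a carboxylic acid or a primary amine in place of the group exchanged here, would give a step beyond the scatter in this assay. Also open, going by these compounds, is whether the same change would leave the number unmoved on any further core, or in any read-out other than this one.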